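Two Limits and One Reduced Aldehyde Side Chain

A few compounds are considered here, and "the series" means these few. Any claim that something is new, unique, unknown or untested is made for them only; others in the source may bear on it.

- Compound 1 `C=C[C@@](C)(/C=C/c1ccc(O)cc1)CCCO`: > 36600 nM (a limit)
- Compound 2 `C=C[C@@](C)(/C=C/c1ccc(O)cc1)CC/C=C(\C)C=O`: > 36600 nM (a limit)

Both entries come from an ADME assay on HEK293 cells (Homo sapiens) for cytotoxicity, with a stated time of 72 h (a higher number here means that more compound is needed for the effect, a lower number that less compound is needed), and neither is an exact number. Compound 2 stands only at a limit of > 36600 nM. The whole record so far is the limit of > 36600 nM in this assay, at which 2 of the 2 values shown sit.

Compound 3 `C=C[C@@](C)(/C=C/c1ccc(O)cc1)CC/C=C(\C)CO` differs from compound 2 in one place: hydroxymethyl in place of formyl on a double-bonded chain carbon bound to a double-bonded chain carbon and a saturated chain carbon. Put simply, it carries hydroxymethyl in place of formyl on a double-bonded chain carbon bound to a double-bonded chain carbon and a saturated chain carbon.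

Going by the values given here, the only measured step is a step that the two limits leave unreadable from compound 1 to compound 2. That step replaced hydroxymethyl with 2-formylprop-1-en-1-yl, so it gives no size or direction to carry over. Compound 1 also carries a hydroxymethyl group, and its limit is > 36600 nM.

No step beyond the usual scatter is therefore expected in this assay, and no direction is favoured. The expected change is a step that the limit leaves unreadable from compound 2 to compound 3. For compound 3 the estimate is 40000 nM, with an expected range of 20000 nM to 80000 nM, and another limit is the likeliest report.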

Compound 3, half-maximal effective concentration: > 36600 nM
Compound 3: a limit, no number; the forecaster's own chance of this, stated with the estimate: 85%; the middle value is on the limit's open side.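

In this assay compound 3 gives > 36600 nM, which is a limit and not a number. No size or direction can therefore be read for the steps linking compound 1, compound 2 and compound 3. What remains open is how formyl and hydroxymethyl compare, and at what concentration any of these compounds would reach the half-maximal effect: the limit of > 36600 nM in this assay, at which 3 of the 3 values shown sit.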